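The source may report more compounds than this note shows. Statements on the series, on what has been measured and on what is new or still open speak of the compounds shown alone.

In an assay on cells for inhibition of HSP60/HSP10 (Homo sapiens), with a stated time of 60 min (a higher number here means a weaker inhibitor, a lower number a stronger inhibitor), compound 1, `O=S(=O)(Nc1ccc(-c2nc3ccccc3o2)cc1)c1ccccc1O`, gives only a limit, > 100000 nM, which is the limit of > 100000 nM in this assay, at which 1 of the 3 values shown sits. Compound 3, `O=S(=O)(Nc1ccc(-c2nc3ccccc3o2)cc1)c1ccccc1C(F)(F)F`, gives 74000 nM in this assay, and the step of an at least 1.3-fold lower number from compound 1 to compound 3 (0.13 log units; that floor lies within the scatter) follows the change (trifluoromethyl in place of hydroxy on an aromatic carbon). Compound 2, `O=S(=O)(Nc1ccc2oc(-c3ccccc3)nc2c1)c1ccccc1O`, has the same atoms as compound 1 joined differently; the difference between the two cores is not broken down here. In this assay compound 2 gives 85000 nM. Compound 4, `O=S(=O)(Nc1ccc2oc(-c3ccccc3)nc2c1)c1ccccc1C(F)(F)F`, is not yet measured and differs from compound 2 by the same change, (trifluoromethyl in place of hydroxy on an aromatic carbon). Since the earlier step of an at least 1.3-fold lower number from compound 1 to compound 3 (0.13 log units; that floor lies within the scatter) reached only a floor within the scatter, a similarly small step is expected here, namely a 1.4-fold lower number from compound 2 to compound 4 (0.15 log units; within the scatter). Compound 4 is therefore estimated at 60000 nM in this assay, between 25000 nM and 150000 nM.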

Compound 4, half-maximal inhibitory concentration: > 100000 nM
Compound 4 gave a limit, no number (the forecaster's own chance of this, stated with the estimate: 30%); middle value at least 1.6-fold (0.22 log units) away from the limit.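

In this assay compound 4 gives only a limit, > 100000 nM. The same change on this second core therefore reads only as an at least 1.1-fold higher number from compound 2 to compound 4 (0.07 log units; that floor lies within the scatter). This shows no measurable gain from trifluoromethyl in place of hydroxy on either core, but it does not show that the change behaves alike or differently on the two cores: the same change on two cores in this assay, an at least 1.3-fold lower number (0.13 log units; that floor lies within the scatter) from compound 1 to compound 3 and an at least 1.1-fold higher number (0.07 log units; that floor lies within the scatter) from compound 2 to compound 4; the limit leaves it open whether they differ

The compounds shown leave open whether another group at this place, such as an amine, a carboxylic acid or a methoxy group, would give a value well clear of the limit that recurs in this series: the limit of > 100000 nM in this assay, at which 2 of the 4 values shown sit. They also leave open how either core would respond to a change made elsewhere in the molecule.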